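A methoxyethoxy replacement on compound 1

The compounds below may be only part of what the source reports. "The series", "measured", "known", "first", "only" and "open" are said of these compounds alone.

Compound 1 `CC#C[C@@H](Cc1nnn[nH]1)c1ccc(OCc2ccc3scc(-c4cccnc4C)c3c2)cc1` stands at the short end of an ADME assay on microsomes from liver (Homo sapiens) for metabolic stability; a lower number here means that the compound disappears faster, a higher number that the compound lasts longer. In this assay compound 1 reads < 0.0667 h, which is a limit of the assay and not a number.

Two relatives have numerical values. Compound 2 `CC#C[C@@H](Cc1nnn[nH]1)c1ccc(OCc2ccc3sc(F)c(-c4ccccc4C)c3c2)cc1` gives 0.0667 h, and compound 3 `CC#C[C@@H](Cc1nnn[nH]1)c1ccc(OCc2ccc3scc(-c4ccc(OCCCS(C)(=O)=O)cc4C)c3c2)cc1` gives 1.28 h.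

Compound 4 `CC#C[C@@H](Cc1nnn[nH]1)c1ccc(OCc2ccc3scc(-c4cc(OCCOC)ccc4C)c3c2)cc1` has not yet been measured. It differs from compound 1 by carrying 5-(2-methoxyethoxy)-2-methylphenyl in place of 2-methylpyridin-3-yl on an aromatic carbon.

Going by the values given here, no measured pair isolates this change, so any forecast is loose. The nearest guide is compound 3 at 1.28 h, which, like compound 4, has a chain on the aryl group at this place of the shared core. On that basis, a rise beyond the usual scatter is expected, though compound 4 is not expected to fully match compound 3. The expected step is an at least 4.4-fold higher number from compound 1 to compound 4 (0.65 log units; beyond the scatter). For compound 4 the estimated half-life is 0.3 h, with an expected range from 0.08 h to 1.1 h.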

Compound 4, half-life: 0.867 h
For compound 4 the middle estimate is 2.9-fold (0.46 log units) below the measured one; the measured number falls inside the stated range.
By their numbers in this assay, from the lowest: compound 2; then compounds 4 and 3 (each within the scatter of the next).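

In this assay, putting 5-(2-methoxyethoxy)-2-methylphenyl in place of 2-methylpyridin-3-yl on this aromatic carbon gives an at least 12-fold higher number from compound 1 to compound 4 (1.11 log units; beyond the scatter). Going by these compounds alone, this is the first readable step at this place, and it shows that the half-life can shift by a large margin through this aryl group alone while the rest of the molecule stays the same. Compound 1 is read only at a limit of the assay and not a number, so the step gives only the smallest size the change can have: the limit of < 0.0667 h in this assay, at which 1 of the 4 values shown sits.

The change swaps the ring nitrogen for carbon and adds the chain in one move, and the compounds shown do not separate the two. Also open, from the compounds shown here alone, is how a simple methoxy group, or a chain ending in an amine or a carboxylic acid, would read at this place.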